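A few compounds are considered here, and "the series" means these few. Any claim that something is new, unique, unknown or untested is made for them only; others in the source may bear on it.

Working notes on the series in an ADME assay on liver for metabolic stability, with Liver microsome (Rattus norvegicus) as the target, using microsomes; on this read-out lower numbers stand for a shorter-lived compound and higher numbers for a longer-lived compound.

Three compounds have numbers. Compound 1 `Cc1nc(-c2cc3cc(OCC(C)C)ccc3[nH]2)sc1C(=O)O` gives 1.61 h and stands second highest of the three: compound 2 `COc1cc([N+](=O)[O-])c2[nH]c(-c3nc(C)c(C(=O)O)s3)cc2c1` gives 0.402 h, and compound 3 `Cc1nc(-c2cc3cc(CNS(C)(=O)=O)cc([N+](=O)[O-])c3[nH]2)sc1C(=O)O` gives 14.6 h. Within the data shown here, the one single-point step with numbers on both sides is a 36-fold higher number from compound 2 to compound 3 (1.56 log units; beyond the scatter). Both neighbours of compound 1 lie beyond the scatter from it.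

Compound 4 `Cc1nc(-c2cc3cc(Oc4ccccc4)ccc3[nH]2)sc1C(=O)O` is not yet measured. It differs from compound 1 by phenyl in place of isobutyl on an oxygen on an aromatic ring. Among the measured compounds shown here, no measured step changes a group on the ether oxygen; the step from compound 2 to compound 3 concerns a different position and a different kind of group, so it does not bear on this change. For the measured compounds named here, with no relevant precedent, the expectation rests on the value of compound 1 alone, and no step beyond the scatter is expected in either direction: the estimated step is a 1.1-fold lower number from compound 1 to compound 4 (0.03 log units; within the scatter).

For compound 4 the expected value in this assay is 1.5 h, with a range from 0.5 h to 4.5 h.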

Compound 4, half-life: 1.94 h
Compound 4: middle estimate off by 1.3-fold (0.11 log units), on the low side; measured number inside the range.
By their numbers in this assay, from the lowest: compound 2; then compounds 1 and 4 (each within the scatter of the next); then compound 3.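

The swap of isobutyl for phenyl on the oxygen on an aromatic ring reads in this assay as a 1.2-fold higher number from compound 1 to compound 4 (0.08 log units; within the scatter), so on this read-out the two groups cannot be told apart in this pair. Among these compounds, this is the first measured step at the ether oxygen, and it shows that a six-membered aromatic ring of carbon only can take the place of a chain with no ring while the two numbers stay within the scatter of each other. No measurement at hand bears on why these two compounds read alike.

Still open, as far as these compounds go, is whether an amine or a carboxylic acid carried on the ether oxygen, or a longer chain there, would stay with compounds 1 and 4 or move beyond the scatter. Equally open, from the compounds shown here alone, is whether a pyridine ring in place of the phenyl would read the same as compound 4.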